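This account rests on a few compounds, and the source may have more. Where it says the series, first, only, none or still open, it means among the compounds named here.

Measured compounds:
- Compound 1, `O=C(O)c1ccccc1-c1ccc(CCc2ncc(-c3ccccc3)[nH]2)cc1`: 4950 nM
- Compound 2, `CCCCc1cnc(CCc2ccc(-c3ccccc3C(=O)O)cc2)[nH]1`: 2710 nM
- Compound 3, `O=C(O)c1ccccc1-c1ccc(CCc2ncc(Cc3ccc(F)cc3)[nH]2)cc1`: 1600 nM

All three share one core and differ only in the group carried on one aromatic carbon. In an in vitro functional assay on cells for agonist activity at Bombesin receptor subtype-3 (Homo sapiens), read by luminescence and calcium flux (a higher number here means that more compound is needed for the effect, a lower number that less compound is needed), compound 2 stands second highest of the three numbers; its nearest neighbour is compound 3, at a 1.7-fold lower number from compound 2 to compound 3 (0.23 log units; within the scatter), and the furthest is compound 1, at a 1.8-fold lower number from compound 1 to compound 2 (0.26 log units; within the scatter), both within the scatter. Going by the values given here, only the step of a 3.1-fold lower number from compound 1 to compound 3 (0.49 log units; beyond the scatter) goes beyond the scatter, and it is modest.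

Compound 4, `CCC(C)(CC)Cc1cnc(CCc2ccc(-c3ccccc3C(=O)O)cc2)[nH]1`, has not yet been measured. It differs from compound 2 in one place: 1-ethyl-1-methylpropyl in place of propyl on a saturated chain carbon bound to an aromatic carbon. The measured steps that bear on this are the two that touch the same position, namely a 1.8-fold lower number from compound 1 to compound 2 (0.26 log units; within the scatter) and a 1.7-fold lower number from compound 2 to compound 3 (0.23 log units; within the scatter); in both, changing the group on that carbon moved the number by less than the scatter. Among the compounds with values here, nothing measured so far speaks to a branched chain of this kind, so the direction is open, and no step beyond the scatter is expected.

For compound 4 in this assay the estimate is 2200 nM, with a range from 700 nM to 6500 nM, which means an expected step of a 1.2-fold lower number from compound 2 to compound 4 (0.09 log units; within the scatter).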

Compound 4, half-maximal effective concentration: 76 nM
The estimate for compound 4 lay 29-fold (1.46 log units) above the measured number, and the stated range ends above it.
By their numbers in this assay, from the lowest: compound 4; then compounds 3, 2 and 1 (each within the scatter of the next, the first and the last beyond it).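

In this assay, going by these compounds alone, replacing propyl with 1-ethyl-1-methylpropyl on a saturated chain carbon bound to an aromatic carbon gives a far larger change (a 36-fold lower number from compound 2 to compound 4 (1.55 log units; beyond the scatter)) than the small steps among the earlier compounds, so this position can respond strongly to the group it carries. The new chain also stands well clear of both ring-bearing groups, with 4-fluorophenyl giving way to 1-ethyl-1-methylpropyl (a 21-fold lower number from compound 3 to compound 4 (1.32 log units; beyond the scatter)) and phenyl to 2-ethyl-2-methylbutyl (a 65-fold lower number from compound 1 to compound 4 (1.81 log units; beyond the scatter)). Compound 2 also carries an open chain, so having a chain rather than a ring is not enough on its own, and what sets compound 4 apart is a branched group of 6 carbons in place of 3, although no measurement here explains why that change has such an effect.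

Going by these compounds, it remains open whether branching or chain size matters more, a question that a straight hexyl chain and a shorter branched isobutyl chain could help to separate. Also open, on these data alone, is how this position would respond to a chain ending in an amine or a hydroxyl group.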